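Adding One Methyl Along the Chain: What to Expect

The compounds below may be only part of what the source reports. "The series", "measured", "known", "first", "only" and "open" are said of these compounds alone.

Compound 1, `CCCC(C)n1ccc2cc(/C(C)=C/C(=O)Nc3ccccc3OCCCC(=O)O)ccc21`, gives 7.8 nM in an assay on Prostate gland for inhibition of steroid 5-alpha-reductase (Rattus norvegicus); a lower number here means a stronger inhibitor, a higher number a weaker inhibitor.
Compound 2, `CCCCC(C)n1ccc2cc(/C(C)=C/C(=O)Nc3ccccc3OCCCC(=O)O)ccc21`, gives 6 nM in this assay.
Compound 3, `CCCCC(c1ccccc1)n1ccc2cc(/C(C)=C/C(=O)Nc3ccccc3OCCCC(=O)O)ccc21`, gives 9.8 nM in this assay.

The three measured compounds share one core and differ only in the group carried on the aromatic nitrogen. Compound 1 and compound 2 are separated by methyl in place of hydrogen on a saturated chain carbon, four bonds along the chain from an aromatic nitrogen, and the step of a 1.3-fold lower number from compound 1 to compound 2 (0.11 log units; within the scatter) is within the scatter. Compound 1 and compound 3 are separated by 1-phenylpentyl in place of 1-methylbutyl on an aromatic nitrogen, with the step of a 1.3-fold higher number from compound 1 to compound 3 (0.10 log units; within the scatter), again within the scatter. Between compound 2 and compound 3 the step of a 1.6-fold higher number from compound 2 to compound 3 (0.21 log units; within the scatter) is likewise within the scatter. None of the three can be called stronger or weaker than the others on these numbers.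

Compound 4, `CCCCCC(c1ccccc1)n1ccc2cc(/C(C)=C/C(=O)Nc3ccccc3OCCCC(=O)O)ccc21`, has not yet been measured. It differs from compound 3 by methyl in place of hydrogen on a saturated chain carbon, five bonds along the chain from an aromatic carbon and an aromatic nitrogen. Among the measured compounds shown here, this is the same kind of change as the one from compound 1 to compound 2, though the place is not identical: in the earlier pair the carbon is four bonds along the chain from an aromatic nitrogen, here it is five bonds along the chain from an aromatic carbon and an aromatic nitrogen. Since the earlier step of this kind, a 1.3-fold lower number from compound 1 to compound 2 (0.11 log units; within the scatter), stayed within the scatter, the step from compound 3 to compound 4 is expected to be small as well, about a 1.2-fold lower number from compound 3 to compound 4 (0.09 log units; within the scatter). Compound 4 is therefore estimated to give 8 nM in this assay, expected to lie between 4 nM and 16 nM.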

Compound 4, half-maximal inhibitory concentration: 25 nM
The estimate for compound 4 lay 3.1-fold (0.49 log units) below the measured number; measured number outside the range, above it.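

In this assay, methyl in place of hydrogen on a saturated chain carbon did not carry over as a constant step from one core to the other, and the two steps differ: the same change on two cores in this assay, a 1.3-fold lower number (0.11 log units; within the scatter) from compound 1 to compound 2 and a 2.6-fold higher number (0.41 log units; beyond the scatter) from compound 3 to compound 4, 3.3-fold (0.52 log units) apart, beyond the scatter of two such steps

The new step, a 2.6-fold higher number from compound 3 to compound 4 (0.41 log units; beyond the scatter), also leaves compound 4 apart from the other two compounds, with a 4.2-fold higher number from compound 2 to compound 4 (0.62 log units; beyond the scatter) and a 3.2-fold higher number from compound 1 to compound 4 (0.51 log units; beyond the scatter), so that 1-phenylhexyl on the aromatic nitrogen gives the weakest inhibitor of the four, although each of these steps is only modest. This does not show why the two steps differ: they rest on a single pair of compounds on each core, the carbon sits at a different place in each pair, and they cannot separate the part of the phenyl group from that of the chain length, nor do they set a rule for any further core.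

The compounds shown leave open whether a longer chain than 1-phenylhexyl would give a still higher number, and how 1-methylhexyl on the aromatic nitrogen would compare with 1-phenylhexyl. They also leave open whether a hydroxyl group or an amine on the chain would change the size of the step.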